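Acyl group swap on the difluoroanilide series

This account rests on a few compounds, and the source may have more. Where it says the series, first, only, none or still open, it means among the compounds named here.

Measured in an assay on HEK293 cells for inhibition of sodium- and chloride-dependent glycine transporter 1 (Homo sapiens), read by scintillation proximity assay (a lower number here means a stronger inhibitor, a higher number a weaker inhibitor), so far:
Compound 1, `CC(C(=O)Nc1cc(F)cc(F)c1)N(C(=O)c1ccc(Cl)cc1)C1CCCCC1`: 3980 nM
Compound 2, `O=C(CCN(C(=O)c1ccc(Cl)cc1)C1CCCCC1)Nc1cc(F)cc(F)c1`: 10000 nM
Compound 3, `CN1CCC(C(=O)N(CC(=O)Nc2cc(F)cc(F)c2)C2CCCCC2)CC1`: > 25100 nM

All three share a core in which a cyclohexyl-bearing amide nitrogen carries an acyl group on one side and a short chain to the difluoroanilide on the other. Compound 1 and compound 2 both carry a chlorophenyl carbonyl and give numbers in this assay. Compound 3 carries a 1-methylpiperidin-4-yl carbonyl instead, and for compound 3 the assay reports only a limit, namely (the limit of > 25100 nM in this assay, at which 1 of the 3 values shown sits), so its place on the scale is known just as weaker than that bound.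

Compound 4, `Cn1ccc(C(=O)N(CC(=O)Nc2cc(F)cc(F)c2)C2CCCCC2)n1`, is the next point: it keeps the whole frame of compound 3 and differs only by 1-methyl-1H-pyrazol-3-yl in place of 1-methylpiperidin-4-yl on a carbonyl carbon. Going by the values given here, no measured pair of compounds covers this change, and the chlorophenyl compounds 1 and 2 carry a different acyl group altogether, so they do not show what a small aromatic heterocycle does in this place. The direction is therefore open; the most that can be said is that the starting point is already at the weak end.

Compound 4 is expected to give 15000 nM in this assay, within a range of 3000 nM to 50000 nM. The step of an at least 1.6-fold lower number from compound 3 to compound 4 (0.22 log units; that floor lies within the scatter) is thus estimated as a modest gain from the limit, with a real chance that compound 4 again returns only a limit.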

Compound 4, half-maximal inhibitory concentration: > 25100 nM
Compound 4 was reported as a limit; the forecaster's own chance of this, stated with the estimate: 40%; middle value at least 1.6-fold (0.22 log units) from the limit.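

Going by these compounds alone, compound 3 and compound 4 both return only a limit, so no step between them can be read: the limit of > 25100 nM in this assay, at which 2 of the 4 values shown sit.

The compounds shown leave open how far either compound lies past that limit, and whether 1-methyl-1H-pyrazol-3-yl in place of 1-methylpiperidin-4-yl on a carbonyl carbon changes the value at all.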